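Dimethylaminomethyl in place of acetamido on the biaryl terminus

The compounds below may be only part of what the source reports. "The series", "measured", "known", "first", "only" and "open" are said of these compounds alone.

Among the measured compounds shown here, compound 2 `CC[C@H](C)[C@H](N)CN(C(=O)[C@@H]1C[C@H]1c1ccccc1)c1ccc(-c2ccc(NC(C)=O)cc2)cc1` carries an acetamido group on the outer aromatic ring and gives 5500 nM in a functional assay for agonist activity at G protein-coupled receptor 88 (Homo sapiens), read by HTRF and cAMP accumulation (on this read-out lower numbers stand for an effect already at smaller amounts and higher numbers for an effect only at larger amounts of compound), the highest number among the two compounds measured so far. For the measured compounds named here, its nearest neighbour is compound 1 `CCCc1ccc(-c2ccc(N(C[C@@H](N)[C@@H](C)CC)C(=O)[C@@H]3C[C@H]3c3ccccc3)cc2)cc1`, the propyl analogue, at 61 nM in this assay; the step of a 90-fold higher number from compound 1 to compound 2 (1.96 log units; beyond the scatter) is the only measured step.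

Compound 3 `CC[C@H](C)[C@H](N)CN(C(=O)[C@@H]1C[C@H]1c1ccccc1)c1ccc(-c2ccc(CN(C)C)cc2)cc1` has not been measured in this assay. The change (dimethylamino)methyl in place of acetamido on an aromatic carbon removes the acetamido group that compound 2 bears and puts in its place a group of the same heavy-atom count without the carbonyl and without a hydrogen-bond donor. Going by the values given here, the single measured step bears on it only in part: it shows that replacing propyl by acetamido at this position costs a large amount, but no measured compound carries a (dimethylamino)methyl group or any other amine-bearing chain there, so the step from compound 2 to compound 3 has no direct precedent.

Taking the loss seen from compound 1 to compound 2 as evidence that the acetamido group is poorly tolerated at this position, compound 3 is expected to move back toward compound 1 without reaching it, an estimated 5.5-fold lower number from compound 2 to compound 3 (0.74 log units; beyond the scatter). The estimate for compound 3 in this assay is 1000 nM, within 200 nM to 5000 nM.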

Compound 3, half-maximal effective concentration: 460 nM
Compound 3: middle estimate off by 2.2-fold (0.34 log units), on the high side, and the stated range covers the measured number.
By their numbers in this assay, from the lowest: compound 1; then compound 3; then compound 2.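

At this position, para to a large group, acetamido does not set the level for every group of its heavy-atom count: in this assay, (dimethylamino)methyl in its place gives a 12-fold lower number from compound 2 to compound 3 (1.08 log units; beyond the scatter), so a nitrogen-bearing group can be carried here with much less loss than compound 2 alone suggested. The recovery is partial, with a 7.5-fold higher number from compound 1 to compound 3 (0.88 log units; beyond the scatter), and the propyl group of compound 1 still gives the lowest number of the three compounds. No measurement in hand gives a reason for either step.

The change from compound 2 to compound 3 removes the carbonyl and the amide hydrogen together and brings in a dimethylamino group, so the compounds shown do not separate these parts from one another. An aminomethyl group, a longer 2-(dimethylamino)ethyl chain or a carboxylic acid at the same place would show whether the level of compound 3 holds for other nitrogen-bearing chains and how far it extends to an acid.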